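The source may hold more compounds than are shown below. What is called first, only, known or untested is meant among the compounds shown, and "the series" means these compounds.

Measured in a functional assay on PC-3 cells (Homo sapiens) for inhibition, read by MTT assay, with a stated time of 48 h, tested at 10 uM; a lower number here means less inhibition of growth, a higher number more inhibition of growth at the concentration tested:
compound 1 `Cc1cc(=O)c2c(O)cc(OCc3ccccc3)c([C@H]3CCN(C)C[C@H]3O)c2o1`: 41%
compound 2 `Cc1cc(=O)c2c(O)cc(OCc3ccc([N+](=O)[O-])cc3)c([C@H]3CCN(C)C[C@H]3O)c2o1`: 23%
compound 3 `CCN(CC)Cc1c(O)c([C@H]2CCN(C)C[C@H]2O)c2oc(C)cc(=O)c2c1O`: 2%

Compound 3 stands lowest of the three, and its gaps to compound 2 and compound 1 both lie beyond the scatter. Compound 4 `Cc1cc(=O)c2c(O)c(CN3CCCC3)c(O)c([C@H]3CCN(C)C[C@H]3O)c2o1` replaces its open diethylamino with the ring-shaped pyrrolidin-1-yl: pyrrolidin-1-yl in place of diethylamino on a saturated chain carbon bound to an aromatic carbon. Going by the values given here, the only measured step, a number 18 percentage points lower from compound 1 to compound 2 (beyond the scatter), is a different kind of change. It offers no direct guide here and shows only how far one change can move this assay. Among the compounds with values here, with no measured step to suggest otherwise, the expected step is small and within the scatter, a number 4 percentage points higher from compound 3 to compound 4 (within the scatter). For compound 4 the estimated value is 6%, with an expected range of 0% to 20%.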

Compound 4, percent growth inhibition at one concentration: 10%
For compound 4 the middle estimate is 4 percentage points below the measured one, and the stated range covers the measured number.
By their numbers in this assay, from the lowest: compounds 3 and 4 (each within the scatter of the next); then compound 2; then compound 1.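

In this assay, closing the open diethylamino into the ring of pyrrolidin-1-yl on this saturated chain carbon gives a number 8 percentage points higher from compound 3 to compound 4 (within the scatter) and so separates the two amines by no more than repeated measurement would. At this place, then, the ring itself makes no readable difference between two groups of equal heavy-atom count. No measurement shown gives a reason for this result. Still open, as far as these compounds go, is whether a six-membered ring such as piperidin-1-yl or morpholin-4-yl, or the shorter dimethylamino, would read any differently on the same carbon.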